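This account rests on a few compounds, and the source may have more. Where it says the series, first, only, none or still open, it means among the compounds named here.

Working notes on the series. In a functional assay on T47D cells (Homo sapiens) for antiproliferative activity, read by MTT assay, with a stated time of 72 h (a higher number here means a weaker inhibitor, a lower number a stronger inhibitor), compound 1 `O=C(Nc1ccc(Cl)c(-c2nnc3c(Cl)cccn23)c1)c1ccc(C(F)(F)F)cc1Cl` gives > 100000 nM, which is a limit of the assay and not a number. Compound 2 `O=C(Nc1ccc(Cl)c(-c2nnc3c(Cl)cccn23)c1)c1ccc(F)cc1Cl` gives > 100000 nM, likewise a limit. Compound 3 `O=C(Nc1ccc(Cl)c(-c2nnc3c(Cl)cccn23)c1)c1ccc(Cl)cc1` gives > 100000 nM, again a limit. Among the measured compounds shown here, the series so far shows only (the limit of > 100000 nM in this assay, at which 3 of the 3 values shown sit); the step that the two limits leave unreadable from compound 1 to compound 2 and the step that the two limits leave unreadable from compound 2 to compound 3 therefore have no readable size. Compound 4 `O=C(Nc1ccc(Cl)c(-c2nnc3c(Cl)cccn23)c1)c1ccc(C(F)(F)F)cc1F` carries fluoro in place of chloro on an aromatic carbon. Neither measured step gives a size that could be carried over to this change, so no shift beyond the scatter can be foreseen in this assay, and a further limit is the likeliest outcome. Compound 4 is expected at 100000 nM, between 30000 nM and 300000 nM. The step of a number no higher from compound 1 to compound 4 (the limit leaves the size open) that this estimate means is expected to remain unreadable.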

Compound 4, half-maximal inhibitory concentration: 70800 nM
Compound 4: middle estimate off by 1.4-fold (0.15 log units), on the high side; the measured number falls inside the stated range.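

Fluoro in place of chloro on this aromatic carbon, ortho to a large group and meta to a trifluoromethyl group, gives an at least 1.4-fold lower number from compound 1 to compound 4 (0.14 log units; that floor lies within the scatter). Among the compounds shown here, compound 4 is the first compound with a number and not a limit, yet the change has no firm size. The comparison in this assay remains one-sided: the limit of > 100000 nM in this assay, at which 3 of the 4 values shown sit.

For the compounds shown here, the true size of this step stays open, and the earlier steps cannot be read. The compounds shown also leave open what an amine or a methoxy group on this carbon would give.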